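The compounds below may be only part of what the source reports. "The series", "measured", "known", "first", "only" and "open" are said of these compounds alone.

Compound 2 `CC(C)OC(=O)N1CCC(CCCC(=O)c2ncco2)CC1` gives 4 nM in an assay on isolated protein for inhibition of Fatty-acid amide hydrolase 1 (Homo sapiens); on this read-out lower numbers stand for stronger inhibition and higher numbers for weaker inhibition. Compound 1 `O=C(CCCC1CCN(C(=O)CC2CCCCC2)CC1)c1ncco1` gives 100 nM in this assay. Among the measured compounds shown here, of these two numbers, that of compound 2 is the lower, and the only measured step, a 25-fold lower number from compound 1 to compound 2 (1.40 log units; beyond the scatter), shows that changing the group carried on the ring nitrogen can move the read-out a long way. Compound 3 `O=C(CCCC1CCN(Cc2ccc(Cl)cc2)CC1)c1ncco1` has not yet been measured. It differs from compound 2 in one place: 4-chlorobenzyl in place of isopropoxycarbonyl on an amine nitrogen in a ring. This is a deeper change than the measured step, since the isopropoxycarbonyl is removed as a whole and a 4-chlorobenzyl takes its place, so the measured step bears on it only as a sign that this position is sensitive. For the measured compounds named here, with no step of the same kind to lean on, the estimate is uncertain, and a move toward weaker inhibition is expected, namely a 75-fold higher number from compound 2 to compound 3 (1.88 log units; beyond the scatter). Compound 3 is therefore expected to give about 300 nM in this assay, within a range from 40 nM to 3000 nM.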

Compound 3, half-maximal inhibitory concentration: 66 nM
For compound 3 the middle estimate is 4.5-fold (0.66 log units) above the measured one; low and high end bracket the measured number.
By their numbers in this assay, from the lowest: compound 2; then compounds 3 and 1 (each within the scatter of the next).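

The step, a 17-fold higher number from compound 2 to compound 3 (1.22 log units; beyond the scatter), shows that the ring nitrogen does not need isopropoxycarbonyl for measurable inhibition in this assay, but that replacing it with 4-chlorobenzyl, which brings a six-membered aromatic ring and has no hydrogen-bond acceptors, gives up much of the strength of compound 2. Compound 1 keeps a carbonyl on the ring nitrogen and compound 3 does not, yet their numbers lie within the scatter of each other, so among these three compounds a carbonyl at this position is not enough to reach the low number of compound 2. Nothing available explains why these groups give such different numbers.

The compounds shown leave open what the chlorine contributes, a question that a plain benzyl on the same nitrogen could answer. They also leave open how closely the low number of compound 2 depends on the isopropyl part of its group, which ethoxycarbonyl or tert-butoxycarbonyl at this position could test.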